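The source may report more compounds than this note shows. Statements on the series, on what has been measured and on what is new or still open speak of the compounds shown alone.

Measured compounds:
compound 1 `COc1cc(/C=N/Nc2nc(-c3ccc(Br)cc3)cs2)cc(Br)c1OC`: 52300 nM in a functional assay on A549 cells (Homo sapiens) for inhibition, read by MTT assay, with a stated time of 48 h; on this read-out higher numbers stand for weaker inhibition and lower numbers for stronger inhibition
compound 2 `COc1cc(/C=N/Nc2nc(-c3ccc(C(F)(F)F)cc3)cs2)c(Br)c(Br)c1OC`: 17600 nM in this assay

Of these two numbers, compound 1 holds the higher one; the gap between compound 1 and compound 2 lies beyond the usual scatter. Compound 3 `COc1cc(/C=N/Nc2nc(-c3ccc(F)c(F)c3)cs2)cc(Br)c1OC` has not yet been measured. It differs from compound 1 by 3,4-difluorophenyl in place of 4-bromophenyl on an aromatic carbon. Going by the values given here, no measured pair of compounds shows the effect of this change, so there is no ground for expecting a shift in either direction. Compound 3 is therefore expected to sit close to compound 1, with the step of a 1.0-fold lower number from compound 1 to compound 3 (0.02 log units; within the scatter) expected to fall within the scatter. In this assay compound 3 is estimated at 50000 nM, within a range from 15000 nM to 160000 nM.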

Compound 3, half-maximal inhibitory concentration: 21100 nM
Beside the measured number, compound 3's estimate is 2.4-fold (0.37 log units) above it; measured number inside the range.
By their numbers in this assay, from the lowest: compounds 2 and 3 (each within the scatter of the next); then compound 1.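

In this assay, going by these compounds alone, 3,4-difluorophenyl in place of 4-bromophenyl gives a 2.5-fold lower number from compound 1 to compound 3 (0.39 log units; beyond the scatter), a modest step and the first reading of any change at this position with the rest of compound 1 held fixed. The aromatic group on this carbon therefore matters to the number, since the step lies beyond the scatter. No measurement shown here explains the step. The compounds shown leave open how an amine or a carboxylic acid on this phenyl group would shift the number, and whether a single fluorine would give the same step.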